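Swapping an aryl group on a triazole ring

The source may report more compounds than this note shows. Statements on the series, on what has been measured and on what is new or still open speak of the compounds shown alone.

Of the compounds shown here, three of a shared core have been tested in an ADME assay on L02 cells (Homo sapiens) for antiproliferative activity, read by MTT assay, with a stated time of 48 h; on this read-out lower numbers stand for stronger inhibition and higher numbers for weaker inhibition. Compound 1 `CC(=O)Nc1ccc(-n2nncc2CN2C(=O)C3(C(C#N)=C(N)Oc4c3c3nc5ccccc5nc3c3ccccc43)c3ccccc32)cc1` gives > 50000 nM, which is a limit of the assay rather than a number. Compound 2 `Cc1ccc(-n2nncc2CN2C(=O)C3(C(C#N)=C(N)Oc4c3c3nc5ccccc5nc3c3ccccc43)c3ccccc32)cc1C` likewise gives > 50000 nM, again a limit. Within the data shown here, compound 3 `CCc1ccccc1-n1nncc1CN1C(=O)C2(C(C#N)=C(N)Oc3c(N)cc4nc5ccccc5nc4c32)c2ccccc21` is the only compound with a true number, giving 22900 nM in this assay. Among the measured compounds shown here, the one single-point change among the measured compounds, a step that the two limits leave unreadable from compound 1 to compound 2, cannot be read in size, since both of its ends sit at the limit of > 50000 nM in this assay, at which 2 of the 3 values shown sit.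

Compound 4 `COc1ccc(OC)c(-n2nncc2CN2C(=O)C3(C(C#N)=C(N)Oc4c(N)cc5nc6ccccc6nc5c43)c3ccccc32)c1` differs from compound 3 in one place: 2,5-dimethoxyphenyl in place of 2-ethylphenyl on an aromatic nitrogen. For the measured compounds named here, no measured pair shares this change, and the one measured step gives no usable size, so there is nothing to carry over. The expectation for this assay is therefore a step from compound 3 to compound 4 of about a 1.1-fold higher number from compound 3 to compound 4 (0.04 log units; within the scatter), which means no change beyond the scatter. Compound 4 is expected to give about 25000 nM in this assay, within a range from 9000 nM to 60000 nM, with a fair chance that, like compounds 1 and 2, only a limit is reported.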

Compound 4, half-maximal inhibitory concentration: > 50000 nM
Compound 4 gave a limit, no number; the forecaster's own chance of this, stated with the estimate: 35%; at least 2.0-fold (0.30 log units) between middle value and limit.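

Among these compounds, this is the first readable step at this position: in this assay, 2,5-dimethoxyphenyl in place of 2-ethylphenyl on an aromatic nitrogen gives an at least 2.1-fold higher number from compound 3 to compound 4 (0.33 log units; beyond the scatter). On the core of compound 3, then, the aryl group on this nitrogen is not a neutral spectator, since changing that group alone moves the read-out beyond the scatter, towards weaker inhibition. Compound 4 gives a limit rather than a number, so the step has a lower bound but no full size, and the real gap could be larger: the limit of > 50000 nM in this assay, at which 3 of the 4 values shown sit.

A single readable step cannot separate the loss of the ethyl group from the arrival of the two methoxy groups, and it cannot tell whether one methoxy group alone would have the same effect. Going by these compounds, it also stays open what an amine or a carboxylic acid on this aryl ring would do on the core of compound 3, and whether any such group would give a lower number than that of compound 3 in this assay.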